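Trifluoromethyl for Fluoro: From Compound 3 to Compound 4

This account rests on a few compounds, and the source may have more. Where it says the series, first, only, none or still open, it means among the compounds named here.

Compound 3 `C[C@H](NC(=O)Nc1cc(F)ccc1F)c1ccccc1` gives the highest number of the three measured in an ADME assay on the whole organism with Oryza sativa as the target, tested at 10 uM (a lower number here means a stronger effect, a higher number a weaker effect of the compound at the concentration tested), at 99%. Compound 2 `C[C@H](NC(=O)Nc1cccc(F)c1)c1ccccc1` gives 88% and compound 1 `C[C@H](NC(=O)Nc1ccccc1F)c1ccccc1` gives 65%; the steps toward compound 3 were a number 11 percentage points higher from compound 2 to compound 3 (beyond the scatter) and a number 34 percentage points higher from compound 1 to compound 3 (beyond the scatter), each fluoro in place of hydrogen on an aromatic carbon. Compound 4 `C[C@H](NC(=O)Nc1cc(C(F)(F)F)ccc1F)c1ccccc1` differs from compound 3 by trifluoromethyl in place of fluoro on an aromatic carbon. For the measured compounds named here, no measured step swaps fluoro for trifluoromethyl, so the two fluoro additions bear only loosely, both having raised the number. Compound 3 already stands near the top of the scale, and the expected step is a number 6 percentage points lower from compound 3 to compound 4 (within the scatter), small or none beyond the scatter. Compound 4 is accordingly estimated at 93%, within 75% to 100%.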

Compound 4, a percentage reported as activity, at one concentration (the size of the read-out at that concentration, not a potency): 87%
Estimate against measurement, compound 4: 6 percentage points above; the range from low to high includes it.
By their numbers in this assay, from the lowest: compound 1; then compounds 4 and 2 (each within the scatter of the next); then compound 3.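

At this place, para to a fluoro group, compound 4 shows that the rise is not tied to fluoro alone: trifluoromethyl on compound 1 also gives a number 22 percentage points higher from compound 1 to compound 4 (beyond the scatter) in this assay. The two groups are not interchangeable, however, as the swap gives a number 12 percentage points lower from compound 3 to compound 4 (beyond the scatter) and so leaves trifluoromethyl with the smaller rise. Nothing at hand accounts for this difference between the two groups. Still open, on these data alone, is how a nitrile, a methoxy group or an amine at this place would compare, and whether a longer chain would lower the number further.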